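A few compounds are considered here, and "the series" means these few. Any claim that something is new, unique, unknown or untested is made for them only; others in the source may bear on it.

Measured so far in a functional assay on A549 cells (Homo sapiens) for cytotoxicity, read by MTT assay, with a stated time of 72 h; on this read-out higher numbers stand for weaker inhibition and lower numbers for stronger inhibition:
- Compound 1 `COc1ccc(/C=N/NC(=O)Nc2cc3c(Nc4ccc(F)c(Cl)c4)ncnc3cc2O[C@H]2CCOC2)cc1` gives 33100 nM
- Compound 2 `COc1cc2ncnc(Nc3ccc(F)c(Cl)c3)c2cc1NC(=O)N/N=C/c1cccc(Br)c1` gives 28100 nM
- Compound 3 `COc1cc2ncnc(Nc3ccc(F)c(Cl)c3)c2cc1NC(=O)N/N=C/c1ccc([N+](=O)[O-])cc1` gives 35100 nM

The three values lie within the usual scatter of one another, so compound 3 stands level with the other two. Compound 4 `COc1ccc(/C=N/NC(=O)Nc2cc3c(Nc4ccc(F)c(Cl)c4)ncnc3cc2OC)cc1` replaces the 4-nitrophenyl of compound 3 with 4-methoxyphenyl, with methoxy in place of nitro on an aromatic carbon, para to a large group (methoxy in place of nitro on an aromatic carbon). For the measured compounds named here, the one comparable measured change, a 1.2-fold higher number from compound 2 to compound 3 (0.10 log units; within the scatter), also swapped a group on this aromatic ring. Compound 4 differs elsewhere on the core from compound 1, which already carries 4-methoxyphenyl. In this assay compound 1 gives 33100 nM. The expected 1.1-fold lower number from compound 3 to compound 4 (0.05 log units; within the scatter) therefore stays within the scatter. For compound 4 the estimated value is 31000 nM, with an expected range of 17000 nM to 55000 nM.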

Compound 4, half-maximal inhibitory concentration: 28100 nM
The estimate for compound 4 lay 1.1-fold (0.04 log units) above the measured number, and the stated range covers the measured number.
By their numbers in this assay, from the lowest: compounds 2, 4, 1 and 3 (each within the scatter of the next).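

In this assay, the result shows that a ring carrying methoxy at this para position stays level with one carrying nitro (a 1.2-fold lower number from compound 3 to compound 4 (0.10 log units; within the scatter)). The 4-methoxyphenyl compound also stays level with the 3-bromophenyl one (no change at the digits printed from compound 2 to compound 4 (within the scatter)), and methyl in place of oxolan-3-yl on the oxygen stays within the scatter too (a 1.2-fold lower number from compound 1 to compound 4 (0.07 log units; within the scatter)). No measurement here offers a reason for these level numbers. As far as these compounds go, whether an amine or a carboxylic acid on this aromatic carbon would move the number beyond the scatter remains open.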